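Removing the nitro group from compound 2

The source may report more compounds than this note shows. Statements on the series, on what has been measured and on what is new or still open speak of the compounds shown alone.

Of the compounds shown here, three sharing one core have been tested in a functional assay on the whole organism (strain Swiss albino) for inhibition, with Mus musculus as the target, with a stated time of 4 h; a lower number here means that less compound is needed, a higher number that more compound is needed for the effect. Compound 1 `COc1ccc(-n2c(Nc3nc(-c4ccc([N+](=O)[O-])cc4)cs3)n[nH]c2=S)cc1` gives 300 mg/kg, compound 3 `O=[N+]([O-])c1ccc(-c2csc(Nc3n[nH]c(=S)n3-c3ccccc3)n2)cc1` gives 300 mg/kg, and compound 2 `COc1ccccc1-n1c(Nc2nc(-c3ccc([N+](=O)[O-])cc3)cs2)n[nH]c1=S` gives 100 mg/kg, the lowest of the three, since a 3.0-fold lower number from compound 1 to compound 2 (0.48 log units; beyond the scatter) and a 3.0-fold higher number from compound 2 to compound 3 (0.48 log units; beyond the scatter) both lie beyond the scatter. Compound 4 `COc1ccccc1-n1c(Nc2nc(-c3ccccc3)cs2)n[nH]c1=S` differs from compound 2 by hydrogen in place of nitro on an aromatic carbon. For the measured compounds named here, none of the measured steps touches this position; all of them concern the methoxy group, so no measured step bears on this change. The expectation for compound 4 in this assay is therefore a step of about a 1.5-fold higher number from compound 2 to compound 4 (0.18 log units; within the scatter), not beyond the scatter. Compound 4 is estimated at 150 mg/kg, with a range from 70 mg/kg to 320 mg/kg.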

Compound 4, minimum effective dose: 300 mg/kg
The estimate for compound 4 lay 2.0-fold (0.30 log units) below the measured number; low and high end bracket the measured number.
By their numbers in this assay, from the lowest: compound 2; then compounds 1, 3 and 4 (each within the scatter of the next).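

Replacing the 4-nitrophenyl with plain phenyl gives a 3.0-fold higher number from compound 2 to compound 4 (0.48 log units; beyond the scatter), so this position does affect the dose needed. Taking away the methoxy group instead gives a step of the same printed size, a 3.0-fold higher number from compound 2 to compound 3 (0.48 log units; beyond the scatter), so the low number of compound 2 is lost with either change. No measurement at hand gives a reason for this step. On these data alone, whether an amine or a nitrile at this place would serve like nitro stays open. So does whether removing nitro from compound 1 or compound 3 would shift their numbers too.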